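Replacing 6-methylpyridin-3-yl with 4-cyanophenyl on the shared core

The source may report more compounds than this note shows. Statements on the series, on what has been measured and on what is new or still open speak of the compounds shown alone.

In an in vitro ADME assay on microsomes from liver (Homo sapiens) for metabolic stability, tested at 1 uM (a higher number here means that the compound lasts longer, a lower number that the compound disappears faster), compound 1 (`Cc1ccc(-c2cc(-c3ccc(S(C)(=O)=O)cc3)cnc2N)cn1`) gives > 5.83 h, which is a limit of the assay and not a number. Its true half-life is therefore not known, and it stands at the long end of the values seen so far. Compound 2 (`CS(=O)(=O)c1ccc(-c2cnc(N)c(-c3ccc(C(F)(F)F)c(F)c3)c2)cc1`) gives a measured 2.05 h. Among the compounds with values here, no measured pair of compounds differs in one place only, so no direct step is available as a guide.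

Compound 3 (`CS(=O)(=O)c1ccc(-c2cnc(N)c(-c3ccc(C#N)cc3)c2)cc1`) carries 4-cyanophenyl in place of the 6-methylpyridin-3-yl of compound 1, on an aromatic carbon ortho to an amino group: 4-cyanophenyl in place of 6-methylpyridin-3-yl on an aromatic carbon. Within the data shown here, with compound 2 at 2.05 h as the only firm number, a shorter half-life is expected in this assay. The expected change is a drop of moderate size, an at least 2.0-fold lower number from compound 1 to compound 3 (0.31 log units; beyond the scatter). For compound 3 the estimated half-life is 2.8 h, within a range of 1.2 h to 5.5 h.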

Compound 3, half-life: > 5.83 h
Compound 3 gave a limit, no number (the forecaster's own chance of this, stated with the estimate: 15%); at least 2.0-fold (0.31 log units) between middle value and limit.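

In this assay compound 1 and compound 3 both stop at a limit and not a number, so no step can be read between them: the limit of > 5.83 h in this assay, at which 2 of the 3 values shown sit.

The compounds shown leave open how long either half-life really is, and whether 4-cyanophenyl in place of 6-methylpyridin-3-yl changes it at all.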